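Benzyl substituent series: sulfonamide in place of amide

A few compounds are considered here, and "the series" means these few. Any claim that something is new, unique, unknown or untested is made for them only; others in the source may bear on it.

Compound 3 `CNC(=O)c1ccc(CNc2cc(-c3ccccn3)nc(NC)n2)cc1` gives 8 nM in a functional assay on HEK293 cells for agonist activity at G-protein coupled receptor 39 (Mus musculus), read by inositol phosphate accumulation (a lower number here means that less compound is needed, a higher number that more compound is needed for the effect), and stands second highest of the three measured compounds: nearest is compound 2 `CNc1nc(NCc2ccc(Cl)cc2)cc(-c2ccccn2)n1` at 3 nM, the step being a 2.7-fold higher number from compound 2 to compound 3 (0.43 log units; beyond the scatter); furthest is compound 1 `CNc1nc(NCc2ccc(S(C)(=O)=O)cc2)cc(-c2ccccn2)n1` at 185 nM, the step being a 23-fold lower number from compound 1 to compound 3 (1.36 log units; beyond the scatter). Compound 4 `CNc1nc(NCc2ccc(NS(C)(=O)=O)cc2)cc(-c2ccccn2)n1` differs from compound 3 by methanesulfonamido in place of methylcarbamoyl on an aromatic carbon. The bearing steps are a 23-fold lower number from compound 1 to compound 3 (1.36 log units; beyond the scatter) and a 62-fold lower number from compound 1 to compound 2 (1.79 log units; beyond the scatter), both large, showing this position moves the number strongly. The entering group keeps a hydrogen-bond donor yet reintroduces the sulfonyl of compound 1, which gave 185 nM, so a modest rise in number is expected. Compound 4 is estimated at 30 nM, range 8 nM to 120 nM. The expected step is a 3.8-fold higher number from compound 3 to compound 4 (0.57 log units; beyond the scatter).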

Compound 4, half-maximal effective concentration: 8 nM
Estimate against measurement, compound 4: 3.8-fold (0.57 log units) above; low and high end bracket the measured number.
By their numbers in this assay, from the lowest: compound 2; then compounds 3 and 4 (each within the scatter of the next); then compound 1.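

A sulfonyl on this aromatic carbon does not by itself bring a high number in this assay: methanesulfonamido in place of methylsulfonyl gives a large drop (a 23-fold lower number from compound 1 to compound 4 (1.36 log units; beyond the scatter)). Methanesulfonamido and methylcarbamoyl cannot be told apart here (no change at the digits printed from compound 3 to compound 4 (within the scatter)), while chloro keeps a modest lead over methanesulfonamido (a 2.7-fold higher number from compound 2 to compound 4 (0.43 log units; beyond the scatter)). No measurement at hand gives a reason for these differences.

Open, from the compounds shown here alone, is whether a carboxylic acid, an amine or a longer chain on this aromatic carbon would stay close to compound 3 and compound 4 or move towards compound 1.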